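Aminothiophene piperazines: aryl to cycloheptyl on the ring nitrogen

The source may hold more compounds than are shown below. What is called first, only, known or untested is meant among the compounds shown, and "the series" means these compounds.

Measured so far:
compound 1 `Nc1scc(CN2CCN(c3ccc([N+](=O)[O-])cc3)CC2)c1C(=O)c1ccc(Cl)cc1` — -17%
compound 2 `Nc1scc(CN2CCN(c3ccc(Cl)c(C(F)(F)F)c3)CC2)c1C(=O)c1ccc(Cl)cc1` — -60%

Both were read in a functional assay on CHO cells with adenosine receptor A1 (Homo sapiens) as the target, read by cAMP accumulation and immunoassay, with a stated time of 6 min, tested at 10 uM; on this read-out higher numbers stand for a weaker effect at the one concentration tested and lower numbers for a stronger effect. Compound 2 stands lowest of the two numbers; its nearest neighbour is compound 1, and the step of a number 43 percentage points lower from compound 1 to compound 2 (beyond the scatter) lies beyond the scatter, so compound 2 is the stronger of the two at the single concentration tested.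

Compound 3 `Nc1scc(CN2CCN(C3CCCCCC3)CC2)c1C(=O)c1ccc(Cl)cc1` has not yet been measured. It differs from compound 2 in one place: cycloheptyl in place of 4-chloro-3-(trifluoromethyl)phenyl on an amine nitrogen in a ring. Among the measured compounds shown here, the only measured step, a number 43 percentage points lower from compound 1 to compound 2 (beyond the scatter), swaps one substituted phenyl for another on the same ring nitrogen and is large. For the measured compounds named here, no measured step removes the aromatic ring altogether or puts a saturated carbocycle in its place, so that step bears on the new change only loosely: it shows that this position is sensitive, not which way a cycloheptyl will move the number. Going by the values given here, with only two points and a change of a different kind, a step back toward the value of compound 1 is expected, but with wide uncertainty, giving a number 30 percentage points higher from compound 2 to compound 3 (beyond the scatter) as the estimated change. For compound 3 the expected read-out in this assay is -30%, with a range from -65% to 5%.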

Compound 3, a percentage reported as activity, at one concentration (the size of the read-out at that concentration, not a potency): -25%
Beside the measured number, compound 3's estimate is 5 percentage points below it; the range from low to high includes it.
By their numbers in this assay, from the lowest: compound 2; then compounds 3 and 1 (each within the scatter of the next).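

In this assay, the step of a number 35 percentage points higher from compound 2 to compound 3 (beyond the scatter) shows that the amine nitrogen in the ring responds not only to a swap between substituted phenyls but also to the loss of the aromatic ring, with cycloheptyl in place of 4-chloro-3-(trifluoromethyl)phenyl. The step of a number 8 percentage points lower from compound 1 to compound 3 (within the scatter) shows that the presence of an aromatic ring on this nitrogen does not by itself set the number: compound 1 carries 4-nitrophenyl, compound 3 carries cycloheptyl, and the two cannot be told apart, which leaves compound 2 as the only one of the three set apart from the others. Nothing available explains either step.

Still open, on these data alone, is whether the number of compound 2 follows the chlorine, the trifluoromethyl or the two together, which a 4-chlorophenyl and a 3-(trifluoromethyl)phenyl on the same nitrogen would help separate. Also open, as far as these compounds go, is whether a cyclohexyl or a benzyl group there would stay with compound 3 or move toward compound 2.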